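Vinyl sulfone enones and growth inhibition of DU-145 cells

This account rests on a few compounds, and the source may have more. Where it says the series, first, only, none or still open, it means among the compounds named here.

Measured compounds:
compound 1 `CSc1ccc(/C=C(\C(=O)c2ccc(Cl)cc2)S(=O)(=O)Cc2ccc(C)cc2)cc1`, 10000 nM
compound 2 `Cc1cc(C)cc(/C=C(\C(=O)c2ccc(Br)cc2)S(=O)(=O)Cc2ccc(F)cc2)c1`, 10000 nM
compound 3 `CSc1ccc(/C=C(\C(=O)c2ccc(Br)cc2)S(=O)(=O)Cc2ccc(C)cc2)cc1`, 10000 nM

In a functional assay on DU-145 cells (Homo sapiens) for inhibition, read by trypan blue exclusion, with a stated time of 96 h (on this read-out lower numbers stand for stronger inhibition of growth and higher numbers for weaker inhibition of growth), compound 1 gives 10000 nM. It stands level with compounds 2 and 3, and the step of no change at the digits printed from compound 1 to compound 3 (within the scatter) lies within the scatter. Compound 4 `COc1ccccc1/C=C(\C(=O)c1ccc(Cl)cc1)S(=O)(=O)Cc1ccc(C)cc1` differs from compound 1 in one place: 2-methoxyphenyl in place of 4-(methylsulfanyl)phenyl on a double-bonded chain carbon bound to a double-bonded chain carbon. Within the data shown here, no measured step exchanges the arene on the double-bonded chain carbon, so the only guide is the flatness of the three numbers in this assay, which all sit at the same value. Compound 4 is therefore expected to show no step beyond the scatter, no change at the digits printed from compound 1 to compound 4 (within the scatter), and its estimated value in this assay is 10000 nM, with a range from 4000 nM to 25000 nM.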

Compound 4, concentration for 50% growth inhibition: 10000 nM
For compound 4 middle estimate and measured number coincide at the digits printed; the range from low to high includes it.
By their numbers in this assay, from the lowest: compounds 1, 2, 3 and 4 (each within the scatter of the next).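

The exchange of 4-(methylsulfanyl)phenyl for 2-methoxyphenyl on a double-bonded chain carbon bound to a double-bonded chain carbon gives, in this assay, no change at the digits printed from compound 1 to compound 4 (within the scatter). Among these compounds, this is the first measured step at this position, since the earlier step touched only the halogen on an aromatic carbon, and it shows that this exchange of one arene for another leaves the read-out flat as well. Nothing available explains this result. The compounds shown leave open whether an amine or a carboxylic acid on this arene would shift the number, and whether any change at this position can lower it.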